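The source may hold more compounds than are shown below. What is called first, only, known or untested is meant among the compounds shown, and "the series" means these compounds.

Measured so far: compound 1 `CCCCCCCCCC[C@@H](O)[C@H](OS(=O)(=O)[O-])[C@H](O)C[S@+]1C[C@@H](O)[C@H](O)[C@H]1CO` with 1500 nM; compound 2 `CCCCCCCC[C@@H](O)[C@H](OS(=O)(=O)[O-])[C@H](O)C[S@+]1C[C@@H](O)[C@H](O)[C@H]1CO` with 1200 nM; compound 3 `CCC[C@@H](O)[C@H](O)[C@H](O)C[S@+]1C[C@@H](O)[C@H](O)[C@H]1CO` with 5000 nM.

In an assay on intestine for inhibition of Maltase-glucoamylase (Homo sapiens) (on this read-out higher numbers stand for weaker inhibition and lower numbers for stronger inhibition), compound 1 stands second highest of the three numbers, with compound 2 nearest and compound 3 furthest. The step of a 1.3-fold lower number from compound 1 to compound 2 (0.10 log units; within the scatter) shows that trimming the chain by an ethyl leaves the read-out unchanged within the scatter. Compound 4 `CCC[C@@H](O)[C@H](OS(=O)(=O)[O-])[C@H](O)C[S@+]1C[C@@H](O)[C@H](O)[C@H]1CO` carries the change (hydrogen in place of heptyl on a saturated chain carbon, four bonds along the chain from an oxygen on a saturated carbon), a far larger cut of the same chain while the sulfate is kept. Among the measured compounds shown here, only the step from compound 1 to compound 2 bears directly on it, and that step was flat. For the measured compounds named here, compound 3, which has the same propyl chain but a hydroxyl where compound 4 has its sulfate, sits higher than compound 1 and compound 2; no single-point step connects it to compound 4, so it can only be read as a hint that a short chain may sit toward the weaker end. For compound 4 a modest rise is therefore expected, a 1.7-fold higher number from compound 1 to compound 4 (0.22 log units; within the scatter), with an estimated value of 2500 nM and a range from 900 nM to 7000 nM.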

Compound 4, half-maximal inhibitory concentration: 4800 nM
Beside the measured number, compound 4's estimate is 1.9-fold (0.28 log units) below it, and the stated range covers the measured number.
By their numbers in this assay, from the lowest: compounds 2 and 1 (each within the scatter of the next); then compounds 4 and 3 (each within the scatter of the next).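

In this assay the large cut does register, with a 3.2-fold higher number from compound 1 to compound 4 (0.51 log units; beyond the scatter) and a 4.0-fold higher number from compound 2 to compound 4 (0.60 log units; beyond the scatter), so among the three sulfate-bearing compounds, chain length at this position shows up once the chain is as short as propyl, which the small ethyl trim could not reveal. With the propyl chain held constant, the sulfate in place of the hydrogen on that oxygen leaves the read-out unchanged within the scatter, with a 1.0-fold lower number from compound 3 to compound 4 (0.02 log units; within the scatter), so the weaker end seen for compound 3 is shared by its sulfate-bearing counterpart. No measurement at hand offers an explanation for these results.

Going by these compounds, at what chain length the read-out begins to rise stays open, and a pentyl chain at this position would help to narrow it. Also open, on these data alone, is whether a carboxylic acid in place of the sulfate, or a chain longer than that of compound 1, would move the read-out.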